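Cytotoxicity notes: a chain in place of phenyl

The source may report more compounds than this note shows. Statements on the series, on what has been measured and on what is new or still open speak of the compounds shown alone.

Measured so far in an ADME assay on Vero cells (Chlorocebus sabaeus) for cytotoxicity, read by sulforhodamine B assay, with a stated time of 3 days; a higher number here means that more compound is tolerated, a lower number that less compound is tolerated:
- compound 1 `CC1=C(C(=O)Nc2ccc(Cl)cc2)C(c2ccccc2)C(C(=O)Nc2ccc(Cl)cc2)=C(C)N1` gives 15 ug/mL
- compound 2 `CC1=C(C(=O)Nc2ccc(Cl)cc2)C(c2ccco2)C(C(=O)Nc2ccc(Cl)cc2)=C(C)N1` gives 24 ug/mL
- compound 3 `CC1=C(C(=O)Nc2ccc(Cl)cc2)C(c2ccncc2)C(C(=O)Nc2ccc(Cl)cc2)=C(C)N1` gives 78 ug/mL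

Compound 1 gives the lowest number of the three: the nearest is compound 2, with a 1.6-fold higher number from compound 1 to compound 2 (0.20 log units; within the scatter), and the furthest is compound 3, with a 5.2-fold higher number from compound 1 to compound 3 (0.72 log units; beyond the scatter). The remaining step is a 3.3-fold higher number from compound 2 to compound 3 (0.51 log units; beyond the scatter).

Compound 4 `CC1=C(C(=O)Nc2ccc(Cl)cc2)C(C/C=C/c2ccccc2)C(C(=O)Nc2ccc(Cl)cc2)=C(C)N1` is not yet measured in this assay. It differs from compound 1 in one place: 3-phenylprop-2-en-1-yl in place of phenyl on a saturated ring carbon. For the measured compounds named here, no measured step bears directly on this change; the steps from compound 1 each exchange one aromatic ring for another, and only the step to compound 3 lies beyond the scatter. With nothing comparable to lean on, no step beyond the scatter is expected, so the estimated step is a 1.1-fold lower number from compound 1 to compound 4 (0.03 log units; within the scatter). Compound 4 is therefore expected near 14 ug/mL, between 5 ug/mL and 40 ug/mL.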

Compound 4, half-maximal cytotoxic concentration: 21 ug/mL
Compound 4: the middle estimate sits 1.5-fold (0.18 log units) below what was measured; the range from low to high includes it.
By their numbers in this assay, from the lowest: compounds 1, 4 and 2 (each within the scatter of the next); then compound 3.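

In this assay, this saturated ring carbon accepts a 3-phenylprop-2-en-1-yl chain in place of a directly attached ring without a step beyond the scatter: a 1.4-fold higher number from compound 1 to compound 4 (0.15 log units; within the scatter), and a 1.1-fold lower number from compound 2 to compound 4 (0.06 log units; within the scatter). Compound 3 remains apart, with a 3.7-fold lower number from compound 3 to compound 4 (0.57 log units; beyond the scatter), so among these four compounds only the pyridin-4-yl group separates from the rest. Nothing available explains these steps.

As far as these compounds go, whether a saturated propyl chain or a longer chain behaves the same way remains open. So does whether pyridin-4-yl at the end of the chain matches the number of compound 3.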